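Adding a hydroxy to compound 2: solubility notes

A few compounds are considered here, and "the series" means these few. Any claim that something is new, unique, unknown or untested is made for them only; others in the source may bear on it.

Measured so far in a physicochemical assay for solubility, using the shake flask method, with a stated time of 12 h; a lower number here means a less soluble compound, a higher number a more soluble compound:
- compound 1 `O=C(/C=C/c1ccc(O)cc1)/C=C/c1cccc(O)c1O`: 120000 nM
- compound 2 `O=C(/C=C/c1ccccc1O)CC(=O)c1ccc(O)c(O)c1`: 77000 nM

Compound 2, at 77000 nM, and compound 1, at 120000 nM, lie within the scatter of each other, so the two values set no order in this assay. Within the data shown here, the two structures differ in more than one place, and the series so far holds no measured pair that isolates a single change.

The next compound is compound 3 `O=C(/C=C/c1cc(O)ccc1O)CC(=O)c1ccc(O)c(O)c1`, which departs from compound 2 in one place: hydroxy in place of hydrogen on an aromatic carbon. This is hydroxy in place of hydrogen on an aromatic carbon, meta to a large group and para to a hydroxy group.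

Among the measured compounds shown here, with no measured step to gauge this change, the expectation starts from compound 2 at 77000 nM, and no shift beyond the scatter is expected in either direction. The expected change is small, an estimated 1.2-fold higher number from compound 2 to compound 3 (0.07 log units; within the scatter). For compound 3 the estimated value is 90000 nM, with an expected range of 35000 nM to 220000 nM.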

Compound 3, solubility: 47000 nM
Beside the measured number, compound 3's estimate is 1.9-fold (0.28 log units) above it; the range from low to high includes it.
By their numbers in this assay, from the lowest: compounds 3, 2 and 1 (each within the scatter of the next, the first and the last beyond it).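

Working notes: in this assay, hydroxy in place of hydrogen on an aromatic carbon, meta to a large group and para to a hydroxy group, gives a 1.6-fold lower number from compound 2 to compound 3 (0.21 log units; within the scatter). Among these compounds, this is the first measured pair that isolates a single change, and it sets no order between the two compounds, so at this position the added hydroxy, with its one hydrogen-bond donor and one hydrogen-bond acceptor, shows no step that can be told apart from the scatter of this assay. Nothing available bears on what lies behind this result.

Open, on these data alone, is whether an amine, a carboxylic acid or a methoxy group in place of hydrogen at this same position would give a step beyond the scatter, and whether hydroxy in place of hydrogen on another aromatic carbon of the shared core would give a step of similar size. With one step in hand, no pattern can be stated, and compound 1 still differs from compound 2 and compound 3 in more than one place.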